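Chain extension in the hydroxamate series on colon cells

A few compounds are considered here, and "the series" means these few. Any claim that something is new, unique, unknown or untested is made for them only; others in the source may bear on it.

Four analogues share a benzothiazole amide bearing a hydroxamic acid on a saturated chain: compound 1 `O=C(CCCCCCC(=O)Nc1nc2ccc([N+](=O)[O-])cc2s1)NO`, compound 2 `O=C(CCCCC(=O)Nc1nc2ccc([N+](=O)[O-])cc2s1)NO`, compound 3 `CCOc1ccc2nc(NC(=O)CCCCC(=O)NO)sc2c1` and the unmeasured compound 4 `CCOc1ccc2nc(NC(=O)CCCCCCC(=O)NO)sc2c1`.

In a functional assay on SW-620 cells (Homo sapiens) for cytotoxicity (on this read-out higher numbers stand for weaker inhibition and lower numbers for stronger inhibition), compound 1 gives 0.29 ug/mL. Compound 2 reaches only a limit of the assay, > 30 ug/mL. Compound 3 gives 9.26 ug/mL.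

The change 2-(hydroxycarbamoyl)ethyl in place of hydroxycarbamoyl on a saturated chain carbon, four bonds along the chain from a carbonyl carbon produces an at least 100-fold lower number from compound 2 to compound 1 (2.01 log units; beyond the scatter); that size is a lower bound because of the limit of > 30 ug/mL in this assay, at which 1 of the 3 values shown sits. The two cores differ by ethoxy in place of nitro on an aromatic carbon, which gives an at least 3.2-fold lower number from compound 2 to compound 3 (0.51 log units; beyond the scatter).

Compound 4 arises from compound 3 by 2-(hydroxycarbamoyl)ethyl in place of hydroxycarbamoyl on a saturated chain carbon, four bonds along the chain from a carbonyl carbon; the place is identical word for word to the earlier pair, so this is the same change. Compound 4 is expected to show a 93-fold lower number from compound 3 to compound 4 (1.97 log units; beyond the scatter), a step similar in direction to an at least 100-fold lower number from compound 2 to compound 1 (2.01 log units; beyond the scatter) but set beside it with caution, since the starting value of compound 3 is a number rather than a limit. Compound 4 is estimated at 0.1 ug/mL, within an expected span of 0.03 ug/mL to 0.5 ug/mL.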

Compound 4, half-maximal inhibitory concentration: 10.4 ug/mL
The estimate for compound 4 lay 100-fold (2.02 log units) below the measured number, outside the stated range (above it).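

In this assay, 2-(hydroxycarbamoyl)ethyl in place of hydroxycarbamoyl gives an at least 100-fold lower number from compound 2 to compound 1 (2.01 log units; beyond the scatter) on the nitro-bearing core but only a 1.1-fold higher number from compound 3 to compound 4 (0.05 log units; within the scatter) on the ethoxy-bearing core, so the step does not carry from one core to the other: the same change on two cores in this assay, an at least 100-fold lower number (2.01 log units; beyond the scatter) from compound 2 to compound 1 and a 1.1-fold higher number (0.05 log units; within the scatter) from compound 3 to compound 4, at least 110-fold (2.06 log units) apart, beyond the scatter of two such steps

Read the other way, ethoxy in place of nitro gives an at least 3.2-fold lower number from compound 2 to compound 3 (0.51 log units; beyond the scatter) with the hydroxycarbamoyl chain and a 36-fold higher number from compound 1 to compound 4 (1.55 log units; beyond the scatter) with the 2-(hydroxycarbamoyl)ethyl chain, so the effect of each change depends on the other in these four compounds: the same change on two cores in this assay, an at least 3.2-fold lower number (0.51 log units; beyond the scatter) from compound 2 to compound 3 and a 36-fold higher number (1.55 log units; beyond the scatter) from compound 1 to compound 4, at least 110-fold (2.06 log units) apart, beyond the scatter of two such steps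

This rests on a single pair of cores and does not show why the step fails to carry, or what the change does on any other core.

Other chains, such as (hydroxycarbamoyl)methyl or 3-(hydroxycarbamoyl)propyl, remain open on both cores. Also open, on these data alone, are an amine or a chlorine in place of nitro and ethoxy, and a carboxylic acid in place of the hydroxycarbamoyl end of the chain.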